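The compounds below may be only part of what the source reports. "The series", "measured", "known", "first", "only" and "open" are said of these compounds alone.

compound 1 `Cc1ccc(SCc2ccc(C(=O)Nc3ccccc3N)cc2)cc1` value 25.1%
compound 2 `CC(C)(C)c1ccc(SCc2ccc(/C=C/C(=O)Nc3ccccc3N)cc2)cc1` value 18.3%

Among the measured compounds shown here, in a functional assay on SMMC-7721 cells (Homo sapiens) for inhibition, read by CCK-8 assay, with a stated time of 72 h, tested at 2 uM (on this read-out lower numbers stand for less inhibition of growth and higher numbers for more inhibition of growth at the one concentration tested), compound 1 and compound 2 lie within the usual scatter of each other, so compound 1 stands apart from nothing measured so far. Compound 3 `Cc1cc(C)cc(SCc2ccc(C(=O)Nc3ccccc3N)cc2)c1` has not yet been measured. Compared with compound 1, it has 3,5-dimethylphenyl in place of 4-methylphenyl on a sulfur and keeps the rest of the structure. For the measured compounds named here, no measured pair shows this change, and no step beyond the scatter is expected in this assay in either direction. The estimated change is a number 1.1 percentage points lower from compound 1 to compound 3 (within the scatter) and stays within the scatter. For compound 3 the expected value is 24% with an estimated range from 12% to 38% as its bounds.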

Compound 3, percent growth inhibition at one concentration: 29.1%
Compound 3: the middle estimate sits 5.1 percentage points below what was measured, within the range that was stated.
By their numbers in this assay, from the lowest: compounds 2, 1 and 3 (each within the scatter of the next, the first and the last beyond it).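

In this assay, among the compounds shown here, the swap of 4-methylphenyl for 3,5-dimethylphenyl on a sulfur gives the first step that can be read at one place: a number 4 percentage points higher from compound 1 to compound 3 (within the scatter). This position therefore takes the group with one more carbon with no step beyond the usual scatter, which the earlier pair, differing in more than one place, could not show. No measurement on hand bears on why this step is so small.

Still open, going by these compounds, is how an amine or a carboxylic acid on the aromatic ring at this sulfur would read in this assay. On these data alone, whether a longer chain there would stay within the scatter of compound 1 is also open.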